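The source may report more compounds than this note shows. Statements on the series, on what has been measured and on what is new or still open speak of the compounds shown alone.

Compound 1 `COc1ccccc1-n1cc(COc2c(/C=C\C(=O)O)ccc(OC)c2CC=C(C)C)nn1`: 41500 nM
Compound 2 `COc1ccc(/C=C\C(=O)O)c(OCc2cn(-c3ccc(NC(=O)c4ccccc4)cc3)nn2)c1CC=C(C)C`: 17200 nM
Compound 3 `COc1ccc(/C=C\C(=O)O)c(OCc2cn(-c3ccccc3F)nn2)c1CC=C(C)C`: 45600 nM

In a functional assay on NCI-H322 cells (Homo sapiens) for cytotoxicity, read by MTT assay, with a stated time of 24 h (on this read-out lower numbers stand for stronger inhibition and higher numbers for weaker inhibition), compound 1 stands second highest of the three numbers. Nearest is compound 3, reached by a 1.1-fold higher number from compound 1 to compound 3 (0.04 log units; within the scatter), a change confined to the substituent on the phenyl at the triazole nitrogen. Compound 2, which carries a different phenyl at that nitrogen, gives a lower number than compound 1, beyond the scatter.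

Compound 4 `COc1ccc(/C=C\C(=O)O)c(OCc2cn(-c3ccc(C#N)cc3)nn2)c1CC=C(C)C` is the next member: 4-cyanophenyl in place of 2-methoxyphenyl on an aromatic nitrogen. Among the compounds with values here, the only measured step on the same position, from compound 1 to compound 3, stayed within the scatter, so the phenyl substituent has so far moved this assay little. The exchange in compound 4 is larger than that one, and the lower number of compound 2 shows that this position can matter. A modest step is expected, a 1.4-fold lower number from compound 1 to compound 4 (0.14 log units; within the scatter), and compound 4 is estimated at 30000 nM (range 12000 nM to 70000 nM).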

Compound 4, half-maximal inhibitory concentration: 18600 nM
Estimate against measurement, compound 4: 1.6-fold (0.21 log units) above; measured number inside the range.
By their numbers in this assay, from the lowest: compounds 2 and 4 (each within the scatter of the next); then compounds 1 and 3 (each within the scatter of the next).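

In this assay, a change at the phenyl on the aromatic nitrogen now gives steps beyond the scatter, though modest ones, with 4-cyanophenyl as the entering group (a 2.2-fold lower number from compound 1 to compound 4 (0.35 log units; beyond the scatter)) and (a 2.5-fold lower number from compound 3 to compound 4 (0.39 log units; beyond the scatter)). Cyano and benzamido stand within the scatter of each other (a 1.1-fold higher number from compound 2 to compound 4 (0.03 log units; within the scatter)), so the small nitrile matches the larger amide at this place. No measured property bears on these steps, and their cause stays unknown.

Open, going by these compounds, is whether an amine or a carboxylic acid in place of the nitrile would stand with compound 4 or with compound 1. A longer chain there is equally untested in the compounds shown.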